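The source may report more compounds than this note shows. Statements on the series, on what has been measured and on what is new or still open speak of the compounds shown alone.

Series notes, step from compound 3 to compound 4.

Compound 1 `Cn1cnnc1SCC(=O)Nc1ccc(-c2nc(-c3ccccc3)c(-c3ccccc3)n2C)cc1` gives 42.8% in a functional assay on MCF7 cells (Homo sapiens) for cytotoxicity, read by MTT assay, with a stated time of 24 h, tested at 1.6 ug/mL; a lower number here means a weaker effect, a higher number a stronger effect of the compound at the concentration tested. Compound 2 `Cn1c(-c2ccc(NC(=O)CSC3=NCCS3)cc2)nc(-c2ccccc2)c1-c1ccccc1` gives 16.2% in this assay, and compound 3 `CCN1CCN(CC(=O)Nc2ccc(-c3nc(-c4ccccc4)c(-c4ccccc4)n3C)cc2)CC1` gives 14.6% in this assay. Compound 3 holds the lowest of the three numbers; its nearest neighbour is compound 2, with a number 1.6 percentage points lower from compound 2 to compound 3 (within the scatter), and its furthest is compound 1, with a number 28.2 percentage points lower from compound 1 to compound 3 (beyond the scatter). Compound 4 `CN(C)/C=C/N1CCN(CC(=O)Nc2ccc(-c3nc(-c4ccccc4)c(-c4ccccc4)n3C)cc2)CC1` has not yet been measured in this assay. It differs from compound 3 in one place: 2-(dimethylamino)ethenyl in place of ethyl on an amine nitrogen in a ring.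

Among the compounds with values here, no measured step alters a group on the amine nitrogen of this ring; the two steps that end at compound 3 exchange the whole group on the chain carbon bound to the carbonyl carbon, and the one that stays closest in kind, a number 1.6 percentage points lower from compound 2 to compound 3 (within the scatter), lies within the scatter. On that basis no step beyond the scatter is expected for this assay here; compound 4 is estimated at 16%, between 5% and 32%, which would mean an expected step of a number 1.4 percentage points higher from compound 3 to compound 4 (within the scatter).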

Compound 4, a percentage reported as activity, at one concentration (the size of the read-out at that concentration, not a potency): 1.9%
Compound 4: the middle estimate sits 14.1 percentage points above what was measured, outside the stated range (below it).
By their numbers in this assay, from the lowest: compound 4; then compounds 3 and 2 (each within the scatter of the next); then compound 1.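

In this assay the group on the amine nitrogen in the ring turns out to be a working position: 2-(dimethylamino)ethenyl in place of ethyl gives a number 12.7 percentage points lower from compound 3 to compound 4 (beyond the scatter) while the rest of the structure stays unchanged. Within the data shown here, the same group, taken as part of the whole exchange on the saturated chain carbon bound to the carbonyl carbon, gives a number 14.3 percentage points lower from compound 2 to compound 4 (beyond the scatter) and a number 40.9 percentage points lower from compound 1 to compound 4 (beyond the scatter) as the only large step, which leaves compound 4 lowest, beyond the scatter of all three others. Nothing measured here bears on why the number falls.

Going by these compounds, whether the drop follows the added nitrogen or the double bond stays open. A saturated 2-(dimethylamino)ethyl chain or a 2-methoxyethyl chain on the same ring nitrogen would separate the two.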